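Methyl on the anilino group of compound 2

A few compounds are considered here, and "the series" means these few. Any claim that something is new, unique, unknown or untested is made for them only; others in the source may bear on it.

compound 1 (`O=C(Nc1ccccc1)c1c(NO)cc(-c2ccc(Cl)cc2)oc1=O`) gives 11000 nM
compound 2 (`Cc1ccc(-c2cc(NO)c(C(=O)Nc3ccccc3)c(=O)o2)cc1`) gives > 20000 nM
compound 3 (`COc1ccc(-c2cc(NO)c(C(=O)Nc3ccccc3)c(=O)o2)cc1`) gives 16200 nM

In an ADME assay on Huh-7 cells (Homo sapiens) for cytotoxicity, read by a luciferase reporter and WST assay, with a stated time of 3 days (on this read-out higher numbers stand for lower toxicity in this test and lower numbers for higher toxicity in this test), compound 2 reads > 20000 nM as a limit and not a number. Compound 4 (`Cc1ccc(NC(=O)c2c(NO)cc(-c3ccc(C)cc3)oc2=O)cc1`) carries methyl in place of hydrogen on an aromatic carbon, anilino becoming (4-methylphenyl)amino (methyl in place of hydrogen on an aromatic carbon) relative to compound 2. The measured steps (an at least 1.8-fold higher number from compound 1 to compound 2 (0.25 log units; that floor lies within the scatter); a 1.5-fold higher number from compound 1 to compound 3 (0.17 log units; within the scatter); an at least 1.2-fold lower number from compound 2 to compound 3 (0.09 log units; that floor lies within the scatter)) all lie within the scatter, but they change another place in the molecule, and none touches the anilino group. They give only weak guidance, and no step beyond the scatter is expected in this assay for this change. The estimated step (an at least 1.1-fold lower number from compound 2 to compound 4 (0.07 log units; that floor lies within the scatter)) is expected to stay within the scatter. For compound 4 the expected value is 17000 nM with an estimated range of 8000 nM to 30000 nM in this read-out.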

Compound 4, half-maximal cytotoxic concentration: > 20000 nM
Compound 4 ended at the assay's limit (the forecaster's own chance of this, stated with the estimate: 45%); middle value at least 1.1-fold (0.07 log units) from the limit.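

In this assay, compound 2 and compound 4 both end at a limit of the assay, so no step between them can be read: the limit of > 20000 nM in this assay, at which 2 of the 4 values shown sit.

As far as these compounds go, whether methyl in place of hydrogen on the anilino group shifts this read-out at all stays open.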